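The source may hold more compounds than are shown below. What is called first, only, known or untested is meant among the compounds shown, and "the series" means these compounds.

Compound 1 `CC1(OC(=O)N2CCC(O[C@H]3CC[C@H](Oc4cnc(S(C)(=O)=O)cn4)CC3)CC2)CC1`: 25.9 nM; compound 2 `C[C@H](CF)OC(=O)N1CCC(O[C@H]2CC[C@H](Oc3cnc(S(C)(=O)=O)cn3)CC2)CC1`: 36.8 nM; compound 3 `CS(=O)(=O)c1cnc(O[C@H]2CC[C@H](OC3CCN(C(=O)Oc4ccccc4)CC3)CC2)cn1`: 9.6 nM, all in a functional assay on isolated protein for agonist activity at Glucose-dependent insulinotropic receptor (Homo sapiens), read by HTRF and cAMP accumulation; a lower number here means that less compound is needed, a higher number that more compound is needed for the effect.

Among these three, compound 3 gives the lowest number, set apart from the others by a 2.7-fold lower number from compound 1 to compound 3 (0.43 log units; beyond the scatter) and a 3.8-fold lower number from compound 2 to compound 3 (0.58 log units; beyond the scatter). Compound 4 `CS(=O)(=O)c1cnc(O[C@H]2CC[C@H](OC3CCN(C(=O)C4(C(F)(F)F)CC4)CC3)CC2)cn1` differs from compound 3 by 1-(trifluoromethyl)cyclopropyl in place of phenoxy on a carbonyl carbon. Among the measured compounds shown here, no measured step removes the oxygen next to the carbonyl group; the two steps that bear on this change only swap the group on that oxygen, and in both the phenyl variant gave the lower number. Compound 4 is expected to move back toward the numbers of compounds 1 and 2, a modest rise read as a 3.1-fold higher number from compound 3 to compound 4 (0.49 log units; beyond the scatter), because a 2.7-fold lower number from compound 1 to compound 3 (0.43 log units; beyond the scatter) and a 3.8-fold lower number from compound 2 to compound 3 (0.58 log units; beyond the scatter) both ran in favour of the phenyl. Compound 4 is therefore estimated at 30 nM in this assay, within 10 nM to 100 nM.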

Compound 4, half-maximal effective concentration: 107 nM
Beside the measured number, compound 4's estimate is 3.6-fold (0.55 log units) below it; measured number outside the range, above it.
By their numbers in this assay, from the lowest: compound 3; then compounds 1 and 2 (each within the scatter of the next); then compound 4.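

In this assay, 1-(trifluoromethyl)cyclopropyl in place of phenoxy on the carbonyl carbon gives an 11-fold higher number from compound 3 to compound 4 (1.05 log units; beyond the scatter), the largest step among these compounds. The same group also compares poorly with the two non-aromatic groups carried on an oxygen, with a 2.9-fold higher number from compound 2 to compound 4 (0.46 log units; beyond the scatter) and a 4.1-fold higher number from compound 1 to compound 4 (0.62 log units; beyond the scatter), so compound 4 stands above all three compounds that keep that oxygen. Nothing shown gives a reason for these rises. The compounds shown do not separate losing the oxygen from the identity of the new group. From the compounds shown here alone, whether a benzyl group or a plain cyclopropyl on the carbonyl carbon would follow compound 4 remains open.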